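The compounds below may be only part of what the source reports. "The series", "measured", "known", "first", "only" and "open" are said of these compounds alone.

In an ADME assay on RAW264.7 cells (Mus musculus) for cytotoxicity, read by MTT assay, with a stated time of 24 h (on this read-out higher numbers stand for lower toxicity in this test and lower numbers for higher toxicity in this test), compound 1 `O=c1oc2ccc(Cl)cc2c(=O)n1-c1ccc(I)cc1F` gives 6900 nM, the lowest of the three numbers shown, though both other compounds sit within the usual scatter of it: compound 3 `O=c1oc2ccc(I)cc2c(=O)n1-c1ccc(I)cc1F` gives 7600 nM and compound 2 `O=C(Nc1ccc(Br)cc1F)c1cc(I)ccc1O` gives 8400 nM. Compound 4 `O=c1oc2ccc(Cl)cc2c(=O)n1-c1ccc(Cl)cc1F` differs from compound 1 by a single exchange: chloro in place of iodo on an aromatic carbon. For the measured compounds named here, the only measured step that bears on it is another halogen swap on an aromatic carbon, a 1.1-fold higher number from compound 1 to compound 3 (0.04 log units; within the scatter), which went the other way round and moved the number by nothing beyond the scatter. Going by the values given here, no other step speaks to this change. A step within the scatter is therefore expected, no change at the digits printed from compound 1 to compound 4 (within the scatter). Compound 4 is estimated at 6900 nM, with a range from 3500 nM to 14000 nM.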

Compound 4, half-maximal cytotoxic concentration: 6800 nM
Beside the measured number, compound 4's estimate is 1.0-fold (0.01 log units) above it; low and high end bracket the measured number.
By their numbers in this assay, from the lowest: compounds 4, 1, 3 and 2 (each within the scatter of the next).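

At the place meta to a fluoro group and para to a large group, chloro in place of iodo gives a 1.0-fold lower number from compound 1 to compound 4 (0.01 log units; within the scatter) in this assay, so this halogen can be exchanged without moving the number beyond the scatter. The earlier step, a 1.1-fold higher number from compound 1 to compound 3 (0.04 log units; within the scatter), concerned a different halogen on the shared core, so both halogen places have now been probed with a swap of this kind. Nothing available here explains this result.

From the compounds shown here alone, whether an amine or a carboxylic acid at this place would also stay within the scatter remains open, as does the effect of a plain hydrogen there.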